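The compounds below may be only part of what the source reports. "The series", "measured", "known", "first", "only" and "open" are said of these compounds alone.

This account follows a series of amide-linked compounds sharing one core, tested in a functional assay on CHO-K1 cells for antagonist activity at melanin-concentrating hormone receptor 1 (Homo sapiens), read by inositol phosphate accumulation, with stated times of 10 min and 45 min; on this read-out higher numbers stand for weaker inhibition and lower numbers for stronger inhibition. Compound 1 `Cc1nc(NCCCNS(C)(=O)=O)nc2ccc(NC(=O)/C=C/c3ccc(OC(F)(F)F)cc3)cc12` gives 32 nM in this assay, the lowest of the three numbers recorded. Compound 2 `C/C(=C\C(=O)Nc1ccc2nc(N3CCC(N4CCCC4=O)CC3)nc(C)c2c1)c1ccc(OC(F)(F)F)cc1` gives 39 nM in this assay, which lies within the scatter of the number for compound 1, so the two cannot be told apart. Compound 3 `Cc1nc(N2CCC(O)(C3CC3)CC2)nc2ccc(NC(=O)/C=C/c3ccc(Cl)cc3Cl)cc12` gives 575 nM in this assay, a gap from compound 1 that lies beyond the scatter.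

The step under consideration leads from compound 1 to compound 4 `COCC(=O)NC1CCN(c2nc(C)c3cc(NC(=O)/C=C/c4ccc(OC(F)(F)F)cc4)ccc3n2)CC1`, which has not yet been measured. The structural change is 4-(((methoxymethyl)carbonyl)amino)piperidin-1-yl in place of (3-(methanesulfonamido)propyl)amino on an aromatic carbon. Both compound 1 and compound 4 keep the same amide-linked trifluoromethoxyphenyl side, and the group that enters is an acylated six-membered ring carrying one hydrogen-bond donor and three acceptors.

Among the measured compounds shown here, no step between measured compounds bearing exactly this change is recorded. The expected step of a 1.1-fold higher number from compound 1 to compound 4 (0.04 log units; within the scatter) is estimated to be none beyond the scatter, because compound 2 gives 39 nM with a comparable ring-bearing group on the same aromatic carbon. Compound 4 is therefore expected to give 35 nM in this assay, with a range from 15 nM to 90 nM.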

Compound 4, half-maximal inhibitory concentration: 14 nM
Compound 4: middle estimate off by 2.5-fold (0.40 log units), on the high side; the measured number lies below the stated range.
By their numbers in this assay, from the lowest: compound 4; then compounds 1 and 2 (each within the scatter of the next); then compound 3.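

Among the compounds shown here, the change on the aromatic carbon between two ring nitrogen atoms gives a 2.3-fold lower number from compound 1 to compound 4 (0.36 log units; beyond the scatter), and it shows what the earlier compounds, which differ in more than one place, could not: with the amide-linked trifluoromethoxyphenyl side held constant, the number in this assay responds to the group at this position alone. The open (3-(methanesulfonamido)propyl)amino chain, which has no ring, can give way to 4-(((methoxymethyl)carbonyl)amino)piperidin-1-yl, with its six-membered non-aromatic ring, and the number does not rise but falls by a modest step beyond the scatter. No measurement shown here accounts for this step.

The single step changes the ring, the sulfonamide and the count of hydrogen-bond donors together, so the compounds shown leave open which of these carries the difference. Also open, going by these compounds, is how a piperidin-1-yl group carrying a free amine or a carboxylic acid in place of the ((methoxymethyl)carbonyl)amino group would read in this assay, and whether a longer chain on that amide would keep the lower number.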